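Fluoro to chloro on the arylsulfonyl group

A few compounds are considered here, and "the series" means these few. Any claim that something is new, unique, unknown or untested is made for them only; others in the source may bear on it.

Measured in a functional assay on SMMC-7721 cells (Homo sapiens) for cytotoxicity, read by MTT assay, with a stated time of 24 h; a higher number here means a weaker inhibitor, a lower number a stronger inhibitor:
compound 1 `CN1C/C(=C\c2cccnc2)C(=O)/C(=C/c2ccccc2F)C1`: 5420 nM
compound 2 `O=C1/C(=C/c2cccnc2)CN(S(=O)(=O)c2ccccc2)C/C1=C\c1ccccc1F`: 19100 nM
compound 3 `O=C1/C(=C/c2cccnc2)CN(S(=O)(=O)c2ccc(F)cc2)C/C1=C\c1ccccc1F`: 9900 nM

Compound 3 stands within the scatter of both other compounds: a 1.8-fold higher number from compound 1 to compound 3 (0.26 log units; within the scatter), and a 1.9-fold lower number from compound 2 to compound 3 (0.29 log units; within the scatter). Compound 4 `O=C1/C(=C/c2cccnc2)CN(S(=O)(=O)c2ccc(Cl)cc2)C/C1=C\c1ccccc1F` has chloro in place of fluoro on an aromatic carbon, para to a large group: chloro in place of fluoro on an aromatic carbon. Among the measured compounds shown here, no measured pair makes this exchange. The closest evidence is fluoro in place of hydrogen on an aromatic carbon, a 1.9-fold lower number from compound 2 to compound 3 (0.29 log units; within the scatter), which stayed within the scatter. No step beyond the scatter is therefore expected in this assay. The estimated step is a 1.0-fold lower number from compound 3 to compound 4 (0.02 log units; within the scatter). For compound 4 the expected value is 9500 nM, with an estimated range of 4800 nM to 19000 nM.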

Compound 4, half-maximal inhibitory concentration: 16100 nM
Compound 4: middle estimate off by 1.7-fold (0.23 log units), on the low side, within the range that was stated.
By their numbers in this assay, from the lowest: compounds 1, 3, 4 and 2 (each within the scatter of the next, the first and the last beyond it).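

In this assay, chloro in place of fluoro (a 1.6-fold higher number from compound 3 to compound 4 (0.21 log units; within the scatter)) and chloro in place of hydrogen (a 1.2-fold lower number from compound 2 to compound 4 (0.07 log units; within the scatter)) both stay within the scatter, so hydrogen, fluoro and chloro on this aromatic carbon are not told apart. The (4-chlorophenyl)sulfonyl group in place of methyl on the ring nitrogen (a 3.0-fold higher number from compound 1 to compound 4 (0.47 log units; beyond the scatter)) lies beyond the scatter, as the phenylsulfonyl step does and the (4-fluorophenyl)sulfonyl step does not. No available evidence accounts for these results. As far as these compounds go, whether a methoxy or an amino group here would move the number beyond the scatter stays open.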